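A few compounds are considered here, and "the series" means these few. Any claim that something is new, unique, unknown or untested is made for them only; others in the source may bear on it.

Working notes on the series. In a functional assay on HL-60 cells (Homo sapiens) for inhibition, read by CCK-8 assay, with a stated time of 48 h (a higher number here means a weaker inhibitor, a lower number a stronger inhibitor), compound 1 `COc1ccc(NC(=S)NCCNS(=O)(=O)c2sccc2-c2ccc(C)cc2Oc2ccc(O)c(O)c2)cc1` gives 4100 nM, the lowest of the two numbers recorded. Compound 3 `O=C(NCCNS(=O)(=O)c1ccc(-c2ccccc2O[C@H]2CC[C@H](O)CC2)s1)Nc1ccc([N+](=O)[O-])cc1` gives 8900 nM, a gap from compound 1 that lies beyond the usual scatter. Compound 2 `COc1ccc(Oc2ccc([N+](=O)[O-])cc2-c2ccsc2S(=O)(=O)N2CCN(C(=S)Nc3ccc(Cl)cc3)CC2)cc1OC` reaches only a limit, > 50000 nM, (the limit of > 50000 nM in this assay, at which 1 of the 3 values shown sits), so no number is available for it. Compound 4 `Cc1ccc(-c2ccsc2S(=O)(=O)NCCNC(=S)Nc2cccc([N+](=O)[O-])c2)c(Oc2ccc(O)c(O)c2)c1` is not yet measured. It differs from compound 1 in one place: 3-nitrophenyl in place of 4-methoxyphenyl on an amide-type nitrogen. Within the data shown here, no measured pair shows this change, so its size is not known; a step of modest size in this assay is expected, more likely toward a higher number than a lower one, though it may still fall within the scatter. Compound 4 is expected to give 5500 nM, with a range from 2000 nM to 16000 nM. That expectation corresponds to a 1.3-fold higher number from compound 1 to compound 4 (0.13 log units; within the scatter).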

Compound 4, half-maximal inhibitory concentration: 3400 nM
The estimate for compound 4 lay 1.6-fold (0.21 log units) above the measured number, and the stated range covers the measured number.
By their numbers in this assay, from the lowest: compounds 4 and 1 (each within the scatter of the next); then compound 3. At a limit, above all of these: compound 2.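

In this assay the series now has its first pair differing in one place. On the amide-type nitrogen, 3-nitrophenyl in place of 4-methoxyphenyl gives a 1.2-fold lower number from compound 1 to compound 4 (0.08 log units; within the scatter) and so leaves the two compounds indistinguishable, showing that this position accepts both aromatic groups without a readable change. No measured evidence shown here bears on this result.

As far as these compounds go, what a carboxylic acid, an amine or a plain alkyl chain would do on this nitrogen stays open. So does whether the same exchange gives a similar step on a different core.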